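Swapping the aromatic group at a limit-bound position

This account rests on a few compounds, and the source may have more. Where it says the series, first, only, none or still open, it means among the compounds named here.

Measured in a functional assay on K562 cells (Homo sapiens) for antiproliferative activity, with a stated time of 72 h (on this read-out lower numbers stand for stronger inhibition and higher numbers for weaker inhibition), as follows:
compound 1 (`CCCCC#Cc1cc([C@@H]2O[C@H](CO)[C@@H](O)[C@H]2O)n2ncnc(N)c12`) gives 2400 nM
compound 2 (`Nc1ncnn2c([C@@H]3O[C@H](CO)[C@@H](O)[C@H]3O)cc(C#Cc3ccc(F)cc3)c12`) gives > 100000 nM (a limit)
compound 3 (`Nc1ncnn2c([C@@H]3O[C@H](CO)[C@@H](O)[C@H]3O)cc(-c3ccc(F)cc3)c12`) gives > 100000 nM (a limit)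

Compound 3 stands at > 100000 nM as a limit and not a number. The change to compound 4 (`Nc1ncnn2c([C@@H]3O[C@H](CO)[C@@H](O)[C@H]3O)cc(-c3ccccc3Cl)c12`) is 2-chlorophenyl in place of 4-fluorophenyl on an aromatic carbon. Bearing on it are two large steps beyond the scatter (an at least 41-fold higher number from compound 1 to compound 3 (1.61 log units; beyond the scatter); an at least 41-fold higher number from compound 1 to compound 2 (1.61 log units; beyond the scatter)), while the step between the two limits stays unreadable (a step that the two limits leave unreadable from compound 2 to compound 3). Compound 4 keeps a six-membered aromatic ring of carbon only at this place, so no step beyond the scatter, in either direction, is expected (an at least 1.2-fold lower number from compound 3 to compound 4 (0.09 log units; that floor lies within the scatter)). Compound 4 is estimated at 80000 nM with an expected range of 20000 nM to 150000 nM and may well report only a limit.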

Compound 4, half-maximal inhibitory concentration: > 100000 nM
Compound 4 was reported as a limit (the forecaster's own chance of this, stated with the estimate: 70%); at least 1.2-fold (0.09 log units) between middle value and limit.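

In this assay compound 4 gives > 100000 nM, again a limit and not a number. Moving to 2-chlorophenyl, with chlorine in place of fluorine, brings no readable value back, and hex-1-yn-1-yl remains the only group here with a number: an at least 41-fold higher number from compound 1 to compound 4 (1.61 log units; beyond the scatter). The steps among compound 2, compound 3 and compound 4 cannot be read, as all three stop at the same ceiling: the limit of > 100000 nM in this assay, at which 3 of the 4 values shown sit.

Any order among those three compounds stays open. Also open, as far as these compounds go, is what a hexyl chain, a shorter alkyne or an amine would give at this place.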